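Chloro on the sulfonyl phenyl: expected tolerance in the cells

The source may hold more compounds than are shown below. What is called first, only, known or untested is meant among the compounds shown, and "the series" means these compounds.

Two members of the series have been measured. For the measured compounds named here, in an ADME assay on HEK-293T cells (Homo sapiens) for cytotoxicity, read by MTT assay, with a stated time of 48 h (a lower number here means that less compound is tolerated, a higher number that more compound is tolerated), compound 1 `O=C(Nc1cnn(-c2ccccc2)c1)c1cccc(NS(=O)(=O)c2ccccc2)c1` gives 110000 nM and compound 2 `Cc1ccc(-n2cc(NC(=O)c3cccc(NS(=O)(=O)c4ccccc4)c3)cn2)cc1` gives 93800 nM; the single measured step, a 1.2-fold lower number from compound 1 to compound 2 (0.07 log units; within the scatter), leaves compound 1 standing alongside compound 2 rather than apart from it. Compound 3 `O=C(Nc1cnn(-c2ccccc2)c1)c1cccc(NS(=O)(=O)c2ccc(Cl)cc2)c1` differs from compound 1 by chloro in place of hydrogen on an aromatic carbon. Going by the values given here, no measured step involves a chloro, and the one comparison at hand stayed within the scatter, so only a small move in this assay is expected. For compound 3 a step of a 1.3-fold lower number from compound 1 to compound 3 (0.11 log units; within the scatter) is expected. Compound 3 is estimated at 85000 nM, within a range from 40000 nM to 200000 nM.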

Compound 3, half-maximal cytotoxic concentration: 120000 nM
Estimate against measurement, compound 3: 1.4-fold (0.15 log units) below; the measured number falls inside the stated range.
By their numbers in this assay, from the lowest: compounds 2, 1 and 3 (each within the scatter of the next).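

Chloro in place of hydrogen on the phenylsulfonyl ring, para to a large group, gives a 1.1-fold higher number from compound 1 to compound 3 (0.04 log units; within the scatter) in this assay. For the compounds shown here, the earlier step covered only a methyl, so this adds a second substituent, and a first change at this position, that stays within the scatter, with the phenyl to 4-chlorophenyl change leaving the tolerated level of the series in place. No available evidence accounts for this result.

From the compounds shown here alone, whether a group of another kind at this position, such as an amine or a carboxylic acid, would give a step beyond the scatter remains open. Also open, going by these compounds, is whether a longer chain here would leave the number equally in place.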